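This account rests on a few compounds, and the source may have more. Where it says the series, first, only, none or still open, it means among the compounds named here.

Compound 1, with structure `Cc1ccccc1CN1CCC(c2noc(COc3ccc(/C=C/C(=O)NO)cc3)n2)CC1`, was tested in an assay on isolated protein for inhibition of protein deacetylase HDAC6 (Homo sapiens), read by fluorescence, with a stated time of 1 h, tested at 100 nM (on this read-out lower numbers stand for less inhibition and higher numbers for more inhibition at the one concentration tested (going by the name of the read-out)), where compound 1 gives 68%. Compound 2, with structure `Cc1cccc(CN2CCC(c3noc(CN(C)c4ncc(C(=O)NO)cn4)n3)CC2)c1`, was tested in the same way, and in this assay compound 2 gives 54%. Of the two numbers measured, compound 2 stands lowest, and its nearest neighbour, compound 1, sits higher by a gap that lies beyond the usual scatter of this kind of measurement. The two compounds differ in more than one place, so their values only show that compound 1 inhibits more strongly than compound 2 at the concentration tested.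

Compound 3, with structure `CN(Cc1nc(C2CCN(Cc3ccc(C#N)cc3)CC2)no1)c1ncc(C(=O)NO)cn1`, has not yet been measured. It differs from compound 2 in one place: 4-cyanophenyl in place of 3-methylphenyl on a saturated chain carbon bound to an amine nitrogen in a ring. For the measured compounds named here, no pair of measured compounds differing in a single place is available, so nothing in the present numbers says what this exchange should do. The step expected from this change is a number 2 percentage points lower from compound 2 to compound 3 (within the scatter), essentially none beyond the scatter in either direction. Compound 3 is therefore estimated at 52%, with a range from 35% to 70%.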

Compound 3, a percentage reported as inhibition, at one concentration (the size of the read-out at that concentration, not a potency): 38%
Compound 3: middle estimate off by 14 percentage points, on the high side; low and high end bracket the measured number.
By their numbers in this assay, from the lowest: compound 3; then compound 2; then compound 1.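

For the compounds shown here, the exchange of 3-methylbenzyl for 4-cyanobenzyl is the first single-place comparison in this set, and in this assay it gives a number 16 percentage points lower from compound 2 to compound 3 (beyond the scatter). This shows that, with the rest of compound 2 held constant, the read-out at the tested concentration responds to the group on this saturated chain carbon bound to an amine nitrogen in a ring, which the earlier pair, differing in more than one place, could not show. Nothing measured here accounts for the size or direction of this step.

The single step changes both the substituent and its numbered place on the phenyl ring, so the compounds shown leave open whether the lower number belongs to the nitrile or to the change of place, a question that 4-methylphenyl and 3-cyanophenyl at this position could separate. They also leave open how an unsubstituted phenyl would read here, and whether the same exchange would give a step of similar size on the core of compound 1.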